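The source may report more compounds than this note shows. Statements on the series, on what has been measured and on what is new or still open speak of the compounds shown alone.

Series notes. Compound 1 `CC(C)Cc1csc(N)c1C(=O)c1ccc(Cl)cc1` and compound 2 `CC(C)(C)Cc1c(-c2ccc(Cl)cc2)sc(N)c1C(=O)c1ccc(Cl)cc1` share the same core and have both been run in an assay on CHO cells for displacement of a labelled ligand from adenosine receptor A1 (Homo sapiens), read by scintillation counting, tested at 10 uM; on this read-out higher numbers stand for more inhibition at the one concentration tested (going by the name of the read-out) and lower numbers for less inhibition. In this assay compound 1 gives 1%. In this assay compound 2 gives 1%. Compound 2 thus stands level with compound 1 at the digits recorded; the two numbers lie within the scatter of each other, so nothing separates them. For the measured compounds named here, no pair of measured compounds differing in one place exists here, so no measured step is available for comparison.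

Compound 3 `CC(C)(C)Cc1c(-c2ccccc2)sc(N)c1C(=O)c1ccc(Cl)cc1` is the next member and has not yet been run. It differs from compound 2 by hydrogen in place of chloro on an aromatic carbon, the same difference read one bond further out being 4-chlorophenyl to phenyl. With compound 1 and compound 2 both sitting at the bottom of the scale in this assay, the step from compound 2 to compound 3 is expected to be none beyond the scatter, a number 1 percentage points higher from compound 2 to compound 3 (within the scatter). Compound 3 is therefore expected to give about 2% in this assay, with a range from 0% to 12%.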

Compound 3, a percentage reported as inhibition, at one concentration (the size of the read-out at that concentration, not a potency): 1%
For compound 3 the middle estimate is 1 percentage points above the measured one, and the stated range covers the measured number.
By their numbers in this assay, from the lowest: compounds 1, 2 and 3 (each within the scatter of the next).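

In this assay, for the compounds shown here, hydrogen in place of chloro on an aromatic carbon gives no change at the digits printed from compound 2 to compound 3 (within the scatter), the first reading of a change at a single place. The 4-chlorophenyl to phenyl difference therefore does not move the number, and the chloro at this position is not what sets the level of compound 2. With all three compounds at the bottom of the scale, this says little about the position itself, and no measurement on hand bears on the reason for the result.

Still open, going by these compounds, is whether a different group on this aromatic carbon, such as an amine, a methoxy group or a carboxylic acid, would lift the number off the bottom of the scale. Also open, on these data alone, is whether the same change from chloro to hydrogen would read the same way in a compound that stands higher on the scale, for example one carrying a longer chain in place of the 2,2-dimethylpropyl group.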